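The source may report more compounds than this note shows. Statements on the series, on what has been measured and on what is new or still open speak of the compounds shown alone.

Measured so far:
compound 1, `C[n+]1ccn(CCNS(=O)(=O)C(F)(F)F)c1/C=N/O`: in a physicochemical assay for lipophilicity (a lower number here means a more polar compound, a higher number a more lipophilic compound), compound 1 gives -1.2
compound 2, `CCCN(CCn1cc[n+](C)c1/C=N/O)S(=O)(=O)C(F)(F)F`: in this assay compound 2 gives -0.69

Both compounds share one core and differ only at the sulfonamide nitrogen. Among the measured compounds shown here, compound 1 stands at the lowest of the two numbers; the only measured step is a number 0.51 log units higher from compound 1 to compound 2 (beyond the scatter), an exchange at the nitrogen rather than at the sulfur. The unmeasured compound 3, `C[n+]1ccn(CCNS(=O)(=O)c2ccccc2)c1/C=N/O`, keeps the core of compound 1 and alters the sulfonyl group itself: phenyl in place of trifluoromethyl on a sulfonyl sulfur. For the measured compounds named here, no measured step covers this exchange, so the one step that bears on it is a number 0.51 log units higher from compound 1 to compound 2 (beyond the scatter), which shows that putting more carbon onto the sulfonamide raised the number by a modest amount. In the change to compound 3 more heavy atoms enter than leave, and a rise in this assay of at least similar size is therefore expected, in the upward direction and beyond the scatter. Compound 3 is estimated at -0.4, within a range of -1.1 to 0.3, which is expected to mean a number 0.80 log units higher from compound 1 to compound 3 (beyond the scatter).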

Compound 3, distribution coefficient: -1.92
For compound 3 the middle estimate is 1.52 log units above the measured one, outside the stated range (below it).
By their numbers in this assay, from the lowest: compound 3; then compound 1; then compound 2.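

Phenyl in place of trifluoromethyl on a sulfonyl sulfur gives a number 0.72 log units lower from compound 1 to compound 3 (beyond the scatter) in this assay and so shows that this position can lower the number, not only raise it. Propyl in place of hydrogen on a sulfonamide nitrogen gave a number 0.51 log units higher from compound 1 to compound 2 (beyond the scatter) at a different place on the molecule, so the two exchanges that add carbon go in opposite directions, and a gain in heavy atoms does not alone set the direction of the change in these compounds. Nothing measured here accounts for the lower number of compound 3.

A single exchange at the sulfur cannot separate what the arrival of the six-membered aromatic ring contributes from what the departure of trifluoromethyl contributes, and a methyl or a cyclohexyl group on the sulfonyl sulfur would bear on that question. On these data alone, it also remains open how a phenyl ring carrying a methoxy group or a carboxylic acid would read in this assay and whether propyl on the sulfonamide nitrogen would shift the number the same way with phenyl on the sulfonyl sulfur.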